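The source may hold more compounds than are shown below. What is called first, only, known or untested is meant among the compounds shown, and "the series" means these compounds.

In a physicochemical assay for metabolic stability, read by HPLC and mass spectrometry, in phosphate buffer, at 37 degrees C, at pH 7.4 (a lower number here means that the compound disappears faster, a higher number that the compound lasts longer), compound 1 `CC(C)(O/N=C(\C(=O)N[C@@H]1C(=O)N(S(=O)(=O)O)[C@@H]1CNC(=O)CN)c1csc(N)n1)C(=O)O` gives 149 h. Compound 3 `CC(C)(O/N=C(\C(=O)N[C@@H]1C(=O)N(S(=O)(=O)O)[C@@H]1Cn1cncn1)c1csc(N)n1)C(=O)O` gives 233 h. These two numbers are separated by a 1.6-fold higher number from compound 1 to compound 3 (0.19 log units; within the scatter), so compound 3 cannot be ranked apart from compound 1. Compound 2 `CC(C)(O/N=C(\C(=O)N[C@@H]1C(=O)N(S(=O)(=O)O)[C@@H]1CN1CCC1=O)c1csc(N)n1)C(=O)O` reads > 1000 h, which is a limit of the assay and not a number.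

The next structure is compound 4 `CC(C)(O/N=C(\C(=O)N[C@@H]1C(=O)N(S(=O)(=O)O)[C@@H]1Cn1cnnc1)c1csc(N)n1)C(=O)O`, still unmeasured. The change is 4H-1,2,4-triazol-4-yl in place of 1H-1,2,4-triazol-1-yl on a saturated chain carbon bound to a saturated ring carbon. In words, this is 4H-1,2,4-triazol-4-yl in place of 1H-1,2,4-triazol-1-yl on a saturated chain carbon bound to a saturated ring carbon, with the same atoms joined differently.

Within the data shown here, all the measured steps replace the group at this same place. Two go beyond the scatter, an at least 6.7-fold higher number from compound 1 to compound 2 (0.82 log units; beyond the scatter) and an at least 4.2-fold lower number from compound 2 to compound 3 (0.63 log units; beyond the scatter), and both involve the 2-oxoazetidin-1-yl group of compound 2, which is not part of the present change. None of the steps exchanges one triazolyl group for the other, so the series gives no direct measure of this swap. The expectation is therefore anchored on compound 3 at 233 h. The expected step is a 1.0-fold higher number from compound 3 to compound 4 (0.01 log units; within the scatter), meaning no change beyond the scatter is expected in this assay. For compound 4 the estimate is 240 h, with an expected range of 115 h to 500 h.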

Compound 4, half-life: 113 h
Estimate against measurement, compound 4: 2.1-fold (0.33 log units) above; the measured number lies below the stated range.
By their numbers in this assay, from the lowest: compounds 4, 1 and 3 (each within the scatter of the next, the first and the last beyond it). At a limit, above all of these: compound 2.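

In this assay, the two triazolyl groups are not interchangeable on this saturated chain carbon: they carry the same atoms and the same counts of donors and acceptors, yet a 2.1-fold lower number from compound 3 to compound 4 (0.31 log units; beyond the scatter), so a different joining of the same atoms alone is enough to give a modest step beyond the scatter. The change does not set compound 4 apart from the aminomethyl-carbonyl-amino side chain, as a 1.3-fold lower number from compound 1 to compound 4 (0.12 log units; within the scatter), which leaves compounds 4, 1 and 3 as a chain in which only the two ends are separated beyond the scatter. Going by these compounds, compound 2 holds a limit and not a number, so the step, an at least 8.8-fold lower number from compound 2 to compound 4 (0.94 log units; beyond the scatter), is a bound only and its true size is unknown: the limit of > 1000 h in this assay, at which 1 of the 4 values shown sits.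

On these data alone, the numbers do not tell what separates the two triazolyl groups in this assay, and whether a similar gap would appear between a 1H-imidazol-1-yl and a 1H-tetrazol-1-yl group at this place remains open. Also open, as far as these compounds go, is whether the gap between the two triazolyl groups would persist with a longer chain linking them to the saturated ring carbon.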